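The source may report more compounds than this note shows. Statements on the series, on what has been measured and on what is new or still open speak of the compounds shown alone.

Measured in an assay on CHO cells for displacement of a labelled ligand from adenosine receptor A1 (Homo sapiens), read by scintillation counting, with a stated time of 3 h; a higher number here means a weaker inhibitor, a lower number a stronger inhibitor:

Compound 1, `CCn1c(-c2ccccc2)nc2c(NC3CCC3)ncnc21`: 6 nM
Compound 2, `CCCn1c(-c2ccccc2)nc2c(NC3CCC3)ncnc21`: 15 nM
Compound 3, `CCn1c(-c2ccccc2)nc2c(NC3CCOC3)ncnc21`: 10 nM

All three compounds share one core and differ only in the chain on the aromatic nitrogen or in the ring carried on the amine nitrogen. The first change is hydrogen in place of methyl on a saturated chain carbon, two bonds along the chain from an aromatic nitrogen. In this assay it gave a 2.5-fold lower number from compound 2 to compound 1 (0.40 log units; beyond the scatter), so shortening the chain by one carbon at that place went with a stronger inhibitor, though the step is only modest. The second change, (oxolan-3-yl in place of cyclobutyl on a nitrogen on an aromatic ring), gave a 1.7-fold higher number from compound 1 to compound 3 (0.22 log units; within the scatter), a step that cannot be separated from the scatter of the measurement. Compound 2 and compound 3 differ in more than one place, and the difference between their cores is not broken down here. Compound 2 gives 15 nM. Compound 3 gives 10 nM. These two values lie within the scatter of each other.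

Compound 4, `Cn1c(-c2ccccc2)nc2c(NC3CCOC3)ncnc21`, has not yet been measured. It differs from compound 3 by hydrogen in place of methyl on a saturated chain carbon bound to an aromatic nitrogen. Among the compounds with values here, this is the same kind of change as the one from compound 2 to compound 1, but not the same: there the methyl left a carbon two bonds along the chain from the aromatic nitrogen, here it leaves a carbon bound directly to that nitrogen. Because the earlier step of a 2.5-fold lower number from compound 2 to compound 1 (0.40 log units; beyond the scatter) was modest, a step of similar or smaller size is expected here, and compound 4 is expected to give 7 nM, between 2.5 nM and 20 nM, which amounts to an expected step of a 1.4-fold lower number from compound 3 to compound 4 (0.15 log units; within the scatter).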

Compound 4, inhibition constant: 8 nM
Compound 4: the middle estimate sits 1.1-fold (0.06 log units) below what was measured; measured number inside the range.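

In this assay, replacing methyl with hydrogen on the saturated chain carbon bound to the aromatic nitrogen gave a 1.3-fold lower number from compound 3 to compound 4 (0.10 log units; within the scatter), so this step alone cannot be told apart from ordinary variation between repeated measurements. Set beside the earlier step, in which the chain was also shortened by one carbon, the two results cannot be separated: the same change on two cores in this assay, a 2.5-fold lower number (0.40 log units; beyond the scatter) from compound 2 to compound 1 and a 1.3-fold lower number (0.10 log units; within the scatter) from compound 3 to compound 4, 2.0-fold (0.30 log units) apart, within the scatter of two such steps. Within the data shown here, this shows no measurable sign that the result of shortening the chain depends on whether the amine nitrogen carries cyclobutyl or oxolan-3-yl, but it does not show that the change carries over at the same size, as only two steps are compared, the newer one cannot be separated from the scatter, and the methyl leaves a different carbon in each.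

The compounds shown leave open how a methyl chain would read on the core of compound 1 and a propyl chain on the core of compound 3, pairings that would compare the same change at the same place on both cores. Also open, from the compounds shown here alone, is what a longer chain such as butyl on the aromatic nitrogen, or a cyclopentyl ring on the amine nitrogen, would give in this assay.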